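From Trifluoromethyl to Fluoro on the Benzyl Group

The source may report more compounds than this note shows. Statements on the series, on what has been measured and on what is new or still open speak of the compounds shown alone.

Of the compounds shown here, two that share one core have been measured so far. In a functional assay on MCF7 cells (Homo sapiens) for inhibition, read by CCK-8 assay, with a stated time of 48 h (on this read-out lower numbers stand for stronger inhibition of growth and higher numbers for weaker inhibition of growth), compound 1 (`CN1CCN(c2ccc(Nc3ncc(Cl)c(NCc4ccccc4)n3)nc2)CC1`) gives 17300 nM and compound 2 (`CN1CCN(c2ccc(Nc3ncc(Cl)c(NCc4ccc(C(F)(F)F)cc4)n3)nc2)CC1`) gives 28400 nM as its concentration for half-maximal effect on growth. Within the data shown here, compound 2 thus lies within the scatter of compound 1, the only other compound with a number, and the pair cannot be told apart.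

Compound 3 (`CN1CCN(c2ccc(Nc3ncc(Cl)c(NCc4ccc(F)cc4)n3)nc2)CC1`) differs from compound 2 at a single place (fluoro in place of trifluoromethyl on an aromatic carbon), with fluoro in place of trifluoromethyl on an aromatic carbon, para to a large group. Among the measured compounds shown here, only one measured step bears on this change. At that same carbon, the step of a 1.6-fold higher number from compound 1 to compound 2 (0.22 log units; within the scatter) stays within the scatter. For the measured compounds named here, no measured compound yet carries fluoro there, so this support is thin, but nothing in the numbers points to a large move in this assay for this exchange. The expected step is a 1.4-fold lower number from compound 2 to compound 3 (0.13 log units; within the scatter) and no more than the scatter. Compound 3 is estimated at about 21000 nM with 10000 nM to 42000 nM as the expected range.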

Compound 3, concentration for 50% growth inhibition: 19300 nM
Beside the measured number, compound 3's estimate is 1.1-fold (0.04 log units) above it, within the range that was stated.
By their numbers in this assay, from the lowest: compounds 1, 3 and 2 (each within the scatter of the next).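

In this assay, the exchange at this aromatic carbon gives a 1.5-fold lower number from compound 2 to compound 3 (0.17 log units; within the scatter), and fluoro in place of hydrogen gives a 1.1-fold higher number from compound 1 to compound 3 (0.05 log units; within the scatter). Hydrogen, fluoro and trifluoromethyl have now all been read at the same carbon, and every step among the three compounds stays within the scatter, where the earlier pair offered only one such step. Even a change from a group of 4 heavy atoms to one of 1 heavy atom, both without hydrogen-bond donors or acceptors, does not separate compound 2 from compound 3 on this read-out, and no other measurement bears on this result.

The three groups shown carry no ring, no net charge and no hydrogen-bond donor or acceptor, so it stays open whether an amine, a carboxylic acid or a hydroxyl group at this carbon would produce a step beyond the scatter. Among these compounds, it is also open whether the same lack of separation would hold for a longer chain at this carbon, or for these exchanges on a core other than the one shared by compound 1, compound 2 and compound 3.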